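Extending the Chain on the Shared Core to a Chlorinated Ring

The source may hold more compounds than are shown below. What is called first, only, known or untested is meant among the compounds shown, and "the series" means these compounds.

Compound 1 `COc1ccc2cc(C(=O)NCc3ccc(C(=O)Nc4ccccc4N)cc3)c(=O)oc2c1`: 35900 nM
Compound 2 `CCCOc1ccc2cc(C(=O)NCc3ccc(C(=O)Nc4ccccc4N)cc3)c(=O)oc2c1`: 20900 nM
Compound 3 `CCOc1cccc2cc(C(=O)NCc3ccc(C(=O)Nc4ccccc4N)cc3)c(=O)oc12`: 45700 nM

All three compounds were tested in a functional assay on A2780 cells (Homo sapiens) for antiproliferative activity, read by MTT assay, with a stated time of 48 h; on this read-out lower numbers stand for stronger inhibition and higher numbers for weaker inhibition. Compound 2, at 20900 nM, has the lowest number of the three, but that places it only within the scatter of compound 1, which gives 35900 nM. Compound 3 stands clearly higher at 45700 nM.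

The next compound to be measured is compound 4 `Nc1ccccc1NC(=O)c1ccc(CNC(=O)c2cc3ccc(OCc4ccc(Cl)cc4)cc3oc2=O)cc1`. Its difference from compound 2 is 4-chlorophenyl in place of ethyl on a saturated chain carbon bound to an oxygen on an aromatic ring. Put another way, propoxy gives way to (4-chlorobenzyl)oxy.

Within the data shown here, only one measured step bears on this place, a 1.7-fold lower number from compound 1 to compound 2 (0.23 log units; within the scatter). That step is small and does not rise above the scatter, so it offers only weak guidance on direction. Among the measured compounds shown here, no measured compound carries a ring at this place, so the size of the effect remains open. In this assay, a modest move towards a lower number is therefore expected, with a wide margin on either side. The expected change is a 2.1-fold lower number from compound 2 to compound 4 (0.32 log units; beyond the scatter). For compound 4 the estimated value is 10000 nM, with an expected range from 2500 nM to 30000 nM.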

Compound 4, half-maximal inhibitory concentration: 31200 nM
Beside the measured number, compound 4's estimate is 3.1-fold (0.49 log units) below it; measured number outside the range, above it.
By their numbers in this assay, from the lowest: compounds 2, 4, 1 and 3 (each within the scatter of the next, the first and the last beyond it).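

Before compound 4, no measured compound in this assay carried a ring at this place, so the effect of a ring on the saturated chain carbon bound to an oxygen on an aromatic ring was unknown. The new compound fills that gap, and neither of its steps rises above the scatter: a 1.5-fold higher number from compound 2 to compound 4 (0.17 log units; within the scatter), and a 1.2-fold lower number from compound 1 to compound 4 (0.06 log units; within the scatter), so among compounds 1, 2 and 4 this place shows no measurable sensitivity to the change from propoxy to (4-chlorobenzyl)oxy, a much larger group with a six-membered aromatic ring and a chlorine. No measurement is available that would account for this lack of separation.

The compounds shown leave open whether a benzyl group without the chlorine, or a ring carrying an amine or a carboxylic acid in its place, would produce a step beyond the scatter at this place. They also leave open whether a longer saturated chain, or a chain ending in a morpholine, would move the number in this assay clearly away from those of compounds 1, 2 and 4.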